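The compounds below may be only part of what the source reports. "The series", "measured", "known", "first", "only" and "open" are said of these compounds alone.

Compound 1 `CNC(=S)N/N=C/c1nccc2cc(F)ccc12` is measured in a functional assay on MIA PaCa-2 cells (Homo sapiens) for cytotoxicity, read by luminescence, with a stated time of 72 h, in the presence of a further agent that is not named here (on this read-out lower numbers stand for stronger inhibition and higher numbers for weaker inhibition), where compound 1 gives 233 nM. Among the three numbers recorded, compound 1 sits second highest: compound 2 `CN(C)C(=S)NN=Cc1nccc2ccccc12` gives 73.7 nM in this assay, and compound 3 `NC(=S)N/N=C/c1nccc2cc(F)ccc12` gives 2040 nM. The only single-site step among these is the change from compound 1 to compound 3, hydrogen in place of methyl on the amide-type nitrogen, which brought an 8.8-fold higher number from compound 1 to compound 3 (0.94 log units; beyond the scatter). Compound 4 `CNC(=S)N/N=C/c1nccc2ccccc12` differs from compound 1 at another site: hydrogen in place of fluoro on an aromatic carbon. Within the data shown here, no measured step reports that change on its own; compound 2 also lacks the fluoro but carries a second methyl on the nitrogen as well, so its number speaks only loosely to the question. The step from compound 1 to compound 4 in this assay is therefore expected to be small, and compound 4 is estimated at 180 nM, within 60 nM to 550 nM. That expected step for compound 4 amounts to a 1.3-fold lower number from compound 1 to compound 4 (0.11 log units; within the scatter).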

Compound 4, half-maximal inhibitory concentration: 331 nM
Estimate against measurement, compound 4: 1.8-fold (0.26 log units) below, and the stated range covers the measured number.
By their numbers in this assay, from the lowest: compound 2; then compounds 1 and 4 (each within the scatter of the next); then compound 3.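

Among these compounds, at this position, on an aromatic carbon of the six-membered aromatic ring of carbon only, the earlier compounds gave no isolated reading of the fluoro; in this assay, hydrogen in its place gives a 1.4-fold higher number from compound 1 to compound 4 (0.15 log units; within the scatter) and so separates compound 4 from compound 1 by no more than the usual scatter. The other single-site change, hydrogen in place of methyl on the amide-type nitrogen, gives an 8.8-fold higher number from compound 1 to compound 3 (0.94 log units; beyond the scatter) and lies beyond the scatter, so of the two sites only that nitrogen shows a readable step. No evidence is available to explain either result.

Going by these compounds, it remains open whether a chloro, a methoxy or an amine at this aromatic carbon would also stay within the scatter. On these data alone, it is also open whether fluoro and hydrogen would stay as close with hydrogen or a second methyl on the nitrogen.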